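This account rests on a few compounds, and the source may have more. Where it says the series, first, only, none or still open, it means among the compounds named here.

Measured in a functional assay on LFCl2A cells (Rattus norvegicus) for cytotoxicity; a higher number here means a weaker inhibitor, a lower number a stronger inhibitor:
- Compound 1 `CC/C=C\C/C=C\C/C=C\C/C=C\C/C=C\C/C=C\CCC(=O)OC[C@@H]1C=CC(=O)[C@@H](C2CCCC=C2C)O1`: 65000 nM
- Compound 2 `CCCCC/C=C\C/C=C\C/C=C\C/C=C\CCCC(=O)OC[C@H]1O[C@H](C2CCCC=C2C)C=CC1=O`: 1 nM

Compound 2 holds the lower number of the two, far below compound 1. Compound 3 `CCCCC/C=C\C/C=C\C/C=C\C/C=C\CCCC(=O)OC[C@H]1O[C@H](CC2=CCCCC2)C=CC1=O` has the same atoms as compound 2, joined differently: (cyclohex-1-en-1-yl)methyl in place of 2-methylcyclohex-2-en-1-yl on a saturated ring carbon. Among the compounds with values here, no measured pair isolates this change, so its size is uncertain. Since compound 2 sits at 1 nM, the lowest number seen, a rise beyond the scatter in this assay is expected rather than a further drop. The expected change is a 300-fold higher number from compound 2 to compound 3 (2.48 log units; beyond the scatter). For compound 3 the estimated value is 300 nM, with a range of 3 nM to 30000 nM.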

Compound 3, half-maximal inhibitory concentration: 7000 nM
Estimate against measurement, compound 3: 23-fold (1.37 log units) below, within the range that was stated.
By their numbers in this assay, from the lowest: compound 2; then compound 3; then compound 1.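

In this assay, rearranging the same atoms on this saturated ring carbon, with (cyclohex-1-en-1-yl)methyl in place of 2-methylcyclohex-2-en-1-yl, gives a 7000-fold higher number from compound 2 to compound 3 (3.85 log units; beyond the scatter). The number of heavy atoms, the six-membered ring and the double bond all stay the same, so at this position the way the atoms are joined is enough to produce a large change. Nothing available explains the size of this step. On these data alone, it remains open whether a phenyl or a saturated cyclohexyl group here would give a low number, and whether a longer ester chain would alter the step.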